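Amide variation on the shared core: compound 3 to compound 4

A few compounds are considered here, and "the series" means these few. Any claim that something is new, unique, unknown or untested is made for them only; others in the source may bear on it.

Measured so far in a functional assay on the whole organism with Mus musculus as the target; a lower number here means that less compound is needed, a higher number that more compound is needed for the effect:
compound 1 `Cc1ccc(-c2nc3cccnc3n2CC(N)=O)cc1`, 50.5 mg/kg
compound 2 `Cc1ccc(-c2nc3cccnc3n2CC(=O)N(C)C)cc1`, 4.7 mg/kg
compound 3 `O=C(Cn1c(-c2ccc(Cl)cc2)nc2cccnc21)N1CCOCC1`, 11.5 mg/kg

Compound 3 stands second highest of the three numbers in this assay ; the nearest is compound 2, the furthest compound 1, and both gaps lie beyond the scatter. Compound 4 `CN(C)CCCNC(=O)Cn1c(-c2ccc(Cl)cc2)nc2cccnc21` is not yet measured. The change from compound 3 is (3-(dimethylamino)propyl)amino in place of morpholin-4-yl on a carbonyl carbon.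

For the measured compounds named here, only one measured step touches the same place: an 11-fold lower number from compound 1 to compound 2 (1.03 log units; beyond the scatter). That step is large and shows the group on the carbonyl carbon matters strongly in this assay , but it went from amino to dimethylamino, whereas here a morpholin-4-yl leaves and a (3-(dimethylamino)propyl)amino enters, a group with one hydrogen-bond donor again. The direction is therefore open; a step of moderate size either way is possible. Compound 4 is expected to give about 14 mg/kg, within 4 mg/kg to 50 mg/kg, and the estimated step of a 1.2-fold higher number from compound 3 to compound 4 (0.09 log units; within the scatter) is thus small relative to the uncertainty.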

Compound 4, dose for half-maximal effect: 64 mg/kg
Beside the measured number, compound 4's estimate is 4.6-fold (0.66 log units) below it, and the stated range ends below it.
By their numbers in this assay, from the lowest: compound 2; then compound 3; then compounds 1 and 4 (each within the scatter of the next).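

In this assay the exchange of morpholin-4-yl for (3-(dimethylamino)propyl)amino gives a 5.6-fold higher number from compound 3 to compound 4 (0.75 log units; beyond the scatter), so the group on the carbonyl carbon matters on the core of compound 3 as well as on the core of compound 1. Set beside an 11-fold lower number from compound 1 to compound 2 (1.03 log units; beyond the scatter), a pattern holds for these two pairs only: the member with the amide hydrogen carries the higher number in each, and neither pair goes against it. Nothing at hand explains either step.

As far as these compounds go, whether the higher number goes with the amide hydrogen, with the loss of the ring or with the dimethylamino end of the chain stays open. A plain propylamino or a piperidin-1-yl on the same carbonyl carbon would begin to separate these features.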